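The source may hold more compounds than are shown below. What is called first, only, known or untested is meant among the compounds shown, and "the series" means these compounds.

Measured so far:
Compound 1, `CCCCOC(=O)Nc1cc2nc(C3CCCCC3)[nH]c2cc1Oc1ccc(F)cc1`: in an ADME assay on Vero cells (Chlorocebus sabaeus) for cytotoxicity, read by MTT assay, with a stated time of 2 days (on this read-out higher numbers stand for weaker inhibition and lower numbers for stronger inhibition), compound 1 gives 60000 nM.
Compound 2, `CCCCSc1cc2[nH]c(C3CCCCC3)nc2cc1NC(=O)c1ccc(F)cc1F`: compound 2 gives only a limit, > 200000 nM.

Compound 2 therefore sits at the limit of > 200000 nM in this assay, at which 1 of the 2 values shown sits, so only a boundary, not a number, is known for it. Compound 3, `O=C(Nc1cc2nc(C3CCCCC3)[nH]c2cc1Oc1ccc(F)cc1)c1ccc(F)cc1F`, differs from compound 2 in one place: 4-fluorophenoxy in place of butylsulfanyl on an aromatic carbon. Going by the values given here, compound 1 carries that same 4-fluorophenoxy group and gives 60000 nM, which suggests compound 3 may give a number of its own, though no measured step of this kind exists, so any change beyond the scatter is uncertain. Compound 3 is expected to give about 100000 nM, with a range from 40000 nM to 300000 nM. The expected change is an at least 2.0-fold lower number from compound 2 to compound 3 (0.30 log units; that floor lies within the scatter).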

Compound 3, half-maximal inhibitory concentration: > 200000 nM
Compound 3: a limit, no number; the forecaster's own chance of this, stated with the estimate: 40%; middle value at least 2.0-fold (0.30 log units) from the limit.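

In this assay compound 3 gives only a limit, > 200000 nM. Going by these compounds alone, the step from compound 2, also a limit, cannot be read, so 4-fluorophenoxy in place of butylsulfanyl has no readable size here, and the one readable change is on the carbonyl carbon, where 2,4-difluorophenyl in place of butoxy gives an at least 3.3-fold higher number from compound 1 to compound 3 (0.52 log units; beyond the scatter). Two compounds now share one boundary: the limit of > 200000 nM in this assay, at which 2 of the 3 values shown sit.

Still open, as far as these compounds go, is how compound 2 and compound 3 truly compare. Also open, from the compounds shown here alone, is whether an amine or a longer chain on that carbonyl carbon would give a number rather than a limit.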